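Aryl exchange on the ethylidene carbon of the acrylic acid series

This account rests on a few compounds, and the source may have more. Where it says the series, first, only, none or still open, it means among the compounds named here.

Compound 1 `CC/C(=C(/c1ccc(/C=C/C(=O)O)cc1)c1cc2ccccc2[nH]1)c1ccccc1OC(F)(F)F` gives 206 nM in a functional assay on MCF7 cells (Homo sapiens) for inhibition; a lower number here means a stronger inhibitor, a higher number a weaker inhibitor.
Compound 2 `CC/C(=C(/c1ccc(/C=C/C(=O)O)cc1)c1cc2ccccc2[nH]1)c1cccc(F)c1C#N` gives 40 nM in this assay.

Within the data shown here, compound 2 holds the lower of the two numbers measured so far, and the only step in hand is a 5.2-fold lower number from compound 1 to compound 2 (0.71 log units; beyond the scatter). That step also swapped the aryl group on the double-bonded chain carbon bound to a double-bonded chain carbon and a saturated chain carbon, and it was modest yet beyond the scatter.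

Compound 3 `CC/C(=C(/c1ccc(/C=C/C(=O)O)cc1)c1cc2ccccc2[nH]1)c1ccc(C#N)cc1Cl` differs from compound 2 by 2-chloro-4-cyanophenyl in place of 2-cyano-3-fluorophenyl on a double-bonded chain carbon bound to a double-bonded chain carbon and a saturated chain carbon. Among the measured compounds shown here, a nitrile and a halogen remain on the ring, but their arrangement changes, and no measured step covers this exact exchange. For the measured compounds named here, with one modest aryl step as the only guide, a change within the scatter or slightly beyond it is expected in this assay, with a lean toward a somewhat higher number. Compound 3 is estimated at 60 nM, within 20 nM to 200 nM. This estimate is expected to mean a 1.5-fold higher number from compound 2 to compound 3 (0.18 log units; within the scatter).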

Compound 3, half-maximal inhibitory concentration: 49 nM
Estimate against measurement, compound 3: 1.2-fold (0.09 log units) above; measured number inside the range.
By their numbers in this assay, from the lowest: compounds 2 and 3 (each within the scatter of the next); then compound 1.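

In this assay the exchange to 2-chloro-4-cyanophenyl in place of 2-cyano-3-fluorophenyl gives a 1.2-fold higher number from compound 2 to compound 3 (0.09 log units; within the scatter) and shows that, on the double-bonded chain carbon, these two arrangements of a nitrile and a halogen cannot be told apart. Replacing 2-(trifluoromethoxy)phenyl with 2-chloro-4-cyanophenyl gives a 4.2-fold lower number from compound 1 to compound 3 (0.62 log units; beyond the scatter) and so repeats the direction of a 5.2-fold lower number from compound 1 to compound 2 (0.71 log units; beyond the scatter): both aryl groups that carry a nitrile and a halogen lie beyond the scatter on the lower side of compound 1, and none of the three compounds goes against this.

Whether the nitrile, the halogen or both account for the gap to compound 1 stays open: every lower-number compound here carries the two together, and an amine in place of the nitrile on this aryl ring would separate them. Nothing shown here gives a measured reason for these numbers.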